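A few compounds are considered here, and "the series" means these few. Any claim that something is new, unique, unknown or untested is made for them only; others in the source may bear on it.

Measured compounds:
- compound 1 `Cc1nc(C)c(-c2csc(Nc3ccc(C(=O)N4C5CNCC4COC5)cn3)n2)s1`: 3.2 nM in an assay on isolated protein for antagonist activity at transient receptor potential cation channel subfamily V member 4 (Homo sapiens); on this read-out higher numbers stand for weaker inhibition and lower numbers for stronger inhibition
- compound 2 `COC(=O)N1CC2CCCC(C1)N2C(=O)c1ccc(Nc2nc(-c3sc(C)nc3C)cs2)nc1`: 1.8 nM in this assay

Compound 1 has the higher of the two numbers, but compound 2 lies within the scatter of it, so the two cannot be ordered. Compound 3 `COC(=O)N1CCN(C(=O)c2ccc(Nc3nc(-c4sc(C)nc4C)cs3)nc2)CC1` differs from compound 1 in one place: a group of 10 heavy atoms (6 carbon, 2 nitrogen, 2 oxygen; one six-membered non-aromatic ring with 2 hetero atoms) in place of a group of 9 heavy atoms (6 carbon, 2 nitrogen, 1 oxygen; 2 six-membered non-aromatic rings with 2 hetero atoms each), on a carbonyl carbon. Within the data shown here, no measured pair shows this change, so the step must be judged from the two values alone. Since compound 2, which also carries a methoxycarbonyl on its ring, gives 1.8 nM, the step of a 1.6-fold higher number from compound 1 to compound 3 (0.19 log units; within the scatter) is expected to be small, leaning towards a somewhat higher number. Compound 3 is estimated at 5 nM, with a range of 1.5 nM to 20 nM.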

Compound 3, half-maximal inhibitory concentration: 37 nM
Compound 3: the middle estimate sits 7.4-fold (0.87 log units) below what was measured, outside the stated range (above it).
By their numbers in this assay, from the lowest: compounds 2 and 1 (each within the scatter of the next); then compound 3.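

The group on the carbonyl carbon is not interchangeable in this assay: replacing the group with 2 six-membered non-aromatic rings by 4-(methoxycarbonyl)piperazin-1-yl gives a 12-fold higher number from compound 1 to compound 3 (1.06 log units; beyond the scatter) and is a large loss of inhibition. The entering group has 0 hydrogen-bond donors against 1 in the group it replaces and one ring instead of 2, and this single pair cannot separate those differences. Nothing available explains the step.

Still open, from the compounds shown here alone, is whether the methoxycarbonyl or the single ring accounts for the loss. Piperazin-1-yl carrying only a hydrogen or an acetyl group in place of methoxycarbonyl would help separate the two.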